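A Methyl Group Removed: What It Means for Clearance

The source may report more compounds than this note shows. Statements on the series, on what has been measured and on what is new or still open speak of the compounds shown alone.

Measured compounds:
compound 1, `Cc1nc2c(F)cccc2n1-c1ccc(C(=O)NC2CC2)s1`: 37 mL/min/kg
compound 2, `Cc1cc(F)c2nc(C)n(-c3ccc(C(=O)NC4CC4)s3)c2c1`: a limit of the assay, > 72 mL/min/kg
compound 3, `Cc1nc2c(Cl)cc(F)cc2n1-c1ccc(C(=O)NC2CC2)s1`: 42 mL/min/kg

In an in vitro ADME assay on microsomes from liver (Mus musculus) for pharmacokinetics, read by LC-MS (on this read-out lower numbers stand for slow clearance and higher numbers for fast clearance), compound 1 gives 37 mL/min/kg and compound 3 gives 42 mL/min/kg, two numbers that lie within the scatter of each other. Among the measured compounds shown here, for compound 2 this assay reports only a limit, > 72 mL/min/kg, and not a number; it is the one value here that sits at the limit of > 72 mL/min/kg in this assay, at which 1 of the 3 values shown sits. The change from compound 2 to compound 1 is hydrogen in place of methyl on an aromatic carbon, and it brings an at least 1.9-fold lower number from compound 2 to compound 1 (0.28 log units; that floor lies within the scatter). The difference between the core of compound 3 and the core of compound 2 is not broken down here.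

Compound 4, `O=C(NC1CC1)c1ccc(-n2cnc3c(Cl)cc(F)cc32)s1`, has not yet been measured. It differs from compound 3 by hydrogen in place of methyl on an aromatic carbon. This is the same kind of change as from compound 2 to compound 1, but not the same: there the methyl left an aromatic carbon of a six-membered aromatic ring of carbon only, meta to a fluoro group, meta to a fused ring and para to a fused ring, whereas here it leaves an aromatic carbon of a five-membered aromatic ring with 2 nitrogen, between two ring nitrogen atoms, next to the ring atom that bears a large group.

Because the earlier step of an at least 1.9-fold lower number from compound 2 to compound 1 (0.28 log units; that floor lies within the scatter) rests on a limit whose floor lies within the scatter, and because the place differs, only a small downward step is expected for compound 4, a 1.3-fold lower number from compound 3 to compound 4 (0.12 log units; within the scatter). Compound 4 is therefore estimated to give 32 mL/min/kg in this assay, between 16 mL/min/kg and 60 mL/min/kg.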

Compound 4, clearance: > 72 mL/min/kg
Compound 4 gave a limit, no number; the forecaster's own chance of this, stated with the estimate: 5%; middle value at least 2.2-fold (0.35 log units) away from the limit.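

Replacing methyl with hydrogen on an aromatic carbon of a five-membered aromatic ring with 2 nitrogen brings an at least 1.7-fold higher number from compound 3 to compound 4 (0.23 log units; that floor lies within the scatter), and the result for compound 4 is a limit of the assay and not a number. Set beside the earlier case, in which the methyl left a different place on a different core, this kind of change does not carry over from one core to the other in this assay: the same change on two cores in this assay, an at least 1.9-fold lower number (0.28 log units; that floor lies within the scatter) from compound 2 to compound 1 and an at least 1.7-fold higher number (0.23 log units; that floor lies within the scatter) from compound 3 to compound 4, at least 3.3-fold (0.52 log units) apart, beyond the scatter of two such steps. This shows that the earlier step cannot simply be transferred within this series, but it does not show whether the place of the methyl or the rest of the core decides the outcome, and neither step has an exact size, as each rests on the same limit: the limit of > 72 mL/min/kg in this assay, at which 2 of the 4 values shown sit.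

The compounds shown leave open whether methyl is special at the carbon between two ring nitrogen atoms, as only methyl and hydrogen appear there, and an ethyl group or an amine at that place would bear on the question. They also leave open what the same change does on the core of compound 1, and how far compound 2 and compound 4 differ from each other in clearance.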